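Swapping isopropyl for iodo on the sulfonate ester phenyl ring

The source may report more compounds than this note shows. Statements on the series, on what has been measured and on what is new or still open speak of the compounds shown alone.

Measured compounds:
compound 1 `CCC(=O)Nc1ccc(S(=O)(=O)Oc2ccccc2I)cc1` 8100 nM
compound 2 `CCCC(=O)Nc1ccc(S(=O)(=O)Oc2ccccc2I)cc1` 9700 nM
compound 3 `CCCCCC(=O)Nc1ccc(S(=O)(=O)Oc2ccccc2C(C)C)cc1` 5300 nM

All three share one core, an amide-bearing aryl sulfonate ester, and were tested in a functional assay on MCF7 cells (Homo sapiens) for antiproliferative activity, read by sulforhodamine B assay, with a stated time of 48 h; on this read-out higher numbers stand for weaker inhibition and lower numbers for stronger inhibition. Compound 3 gives the lowest of the three numbers, yet its gaps to compound 1 and to compound 2 both lie within the usual scatter, so the three cannot be told apart on these data. Among the measured compounds shown here, the one measured step, a 1.2-fold higher number from compound 1 to compound 2 (0.08 log units; within the scatter), concerns the amide chain and stays within the scatter as well.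

Compound 4 `CCCCCC(=O)Nc1ccc(S(=O)(=O)Oc2ccccc2I)cc1` differs from compound 3 by iodo in place of isopropyl on an aromatic carbon. For the measured compounds named here, no measured step touches this part of the molecule, so the change is unanchored. What the numbers do show is that compound 1 and compound 2, which already carry the iodo group with shorter amide chains, sit within the scatter of compound 3, which carries isopropyl and the longer chain. On that basis no step beyond the scatter is expected, and the estimated change a 1.3-fold higher number from compound 3 to compound 4 (0.12 log units; within the scatter) is small in either direction. Compound 4 is therefore expected to give about 7000 nM in this assay, with a range from 3000 nM to 16000 nM.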

Compound 4, half-maximal inhibitory concentration: 10000 nM
Beside the measured number, compound 4's estimate is 1.4-fold (0.15 log units) below it; low and high end bracket the measured number.
By their numbers in this assay, from the lowest: compounds 3, 1, 2 and 4 (each within the scatter of the next).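

Compound 4 gives the first direct view of this position with the amide chain held fixed: in this assay, replacing isopropyl with iodo on the aromatic carbon gives a 1.9-fold higher number from compound 3 to compound 4 (0.28 log units; within the scatter), so these two groups cannot be told apart here, although the step lies closer to the edge of the scatter than any other step in this set. Compound 4 also shows the chain on its own with iodo kept in place, as ethyl in place of hydrogen gives a 1.0-fold higher number from compound 2 to compound 4 (0.01 log units; within the scatter) and propyl in place of hydrogen gives a 1.2-fold higher number from compound 1 to compound 4 (0.09 log units; within the scatter), so neither of these chain changes separates the compounds either. No evidence is available that would explain any of these results.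

As far as these compounds go, with only isopropyl and iodo seen on this aromatic carbon, it remains open whether a very different group there, such as an amine or a carboxylic acid, would give a step beyond the scatter. It is also open whether a much longer chain on the amide carbonyl, or isopropyl paired with a shorter chain, would separate from the compounds shown.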